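This account rests on a few compounds, and the source may have more. Where it says the series, first, only, none or still open, it means among the compounds named here.

Compound 1 `Nc1cccc(/C=C2\SC(=O)N(Cc3cccc(F)c3)C2=O)c1` in a functional assay on FM3A cells (Mus musculus) for cytotoxicity, read by cell counting, with a stated time of 2 days (a lower number here means a stronger inhibitor, a higher number a weaker inhibitor), gives > 250000 nM, which is a limit of the assay rather than a number. Compound 2 `Nc1ccc(/C=C2\SC(=O)N(Cc3cccc(F)c3)C2=O)cc1` gives 121000 nM in this assay, and compound 3 `C=C(Br)C(=O)Nc1ccc(/C=C2\SC(=O)N(Cc3cccc(F)c3)C2=O)cc1` gives 4000 nM. Among the numbers shown, compound 2 stands highest. The measured steps are an at least 2.0-fold lower number from compound 1 to compound 2 (0.31 log units; beyond the scatter) and a 30-fold lower number from compound 2 to compound 3 (1.48 log units; beyond the scatter). Compound 4 `CN1C(=O)S/C(=C\c2ccc(N)cc2)C1=O` differs from compound 2 by hydrogen in place of 3-fluorophenyl on a saturated chain carbon bound to an amide-type nitrogen in a ring. Neither measured step touches that place: one exchanges the position of the amino group on the aromatic ring, the other adds a group to its nitrogen. For the measured compounds named here, no measured step therefore bears directly on this change, and the expectation is uncertain. Compound 4 is expected to give about 200000 nM, between 60000 nM and 500000 nM. That would be an expected step of a 1.7-fold higher number from compound 2 to compound 4 (0.22 log units; within the scatter).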

Compound 4, half-maximal inhibitory concentration: 107000 nM
Compound 4: the middle estimate sits 1.9-fold (0.27 log units) above what was measured; low and high end bracket the measured number.
By their numbers in this assay, from the lowest: compound 3; then compounds 4 and 2 (each within the scatter of the next). At a limit, above all of these: compound 1.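

In this assay, hydrogen in place of 3-fluorophenyl gives a 1.1-fold lower number from compound 2 to compound 4 (0.05 log units; within the scatter). For the compounds shown here, compounds 2 and 4 therefore cannot be told apart, so in this pair the aromatic ring at this place is not needed for the measured cytotoxicity, whereas the earlier steps changed only the amino end of the molecule. Nothing shown explains this result. On these data alone, it remains open whether the same holds with the (1-bromoethenyl)carbonyl group of compound 3 on the nitrogen. Also open, as far as these compounds go, is how a longer chain, an amine or a carboxylic acid would behave at this place.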